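Swapping the aryl group on the oxazole core

This account rests on a few compounds, and the source may have more. Where it says the series, first, only, none or still open, it means among the compounds named here.

Measured compounds:
compound 1, `Nc1ccc(-c2cnc(C(=O)CCCCCCc3ccccc3)o2)cc1`, 90 nM
compound 2, `N#Cc1ccc(-c2cnc(C(=O)CCCCCCc3ccccc3)o2)cc1`, 40 nM

Compound 1 and compound 2 share a core that carries a phenyl-capped chain on one side and an aromatic ring on the other, and were tested in an assay (Rattus norvegicus) for inhibition of Fatty-acid amide hydrolase 1 (Homo sapiens); a higher number here means a weaker inhibitor, a lower number a stronger inhibitor. Compound 2 has the lower of the two numbers: the step of a 2.3-fold lower number from compound 1 to compound 2 (0.35 log units; beyond the scatter) is modest but lies beyond the scatter.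

Compound 3, `O=C(CCCCCCc1ccccc1)c1ncc(-c2ncccc2C(=O)O)o1`, has not yet been measured. It differs from compound 2 by 3-carboxypyridin-2-yl in place of 4-cyanophenyl on an aromatic carbon. Among the measured compounds shown here, the only step known so far is the one from compound 1 to compound 2, and it exchanged one small group for another on the same phenyl ring. The change to compound 3 replaces the whole ring and adds a carboxylic acid, so that step gives little guidance about either direction or size. The number for compound 3 is therefore expected to fall somewhere near that of compound 2, with a wide spread, and the estimated step of a 3.0-fold higher number from compound 2 to compound 3 (0.48 log units; beyond the scatter) could go either way. On balance the estimate for compound 3 is 120 nM, with a range from 25 nM to 700 nM.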

Compound 3, inhibition constant: > 50 nM
Compound 3: a limit, no number; the forecaster's own chance of this, stated with the estimate: 5%; the middle value does not contradict the limit.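

Compound 3 is the first in this set to change the whole aromatic ring on the shared core rather than a small group on it, and in this assay its result is a limit of the assay, not a number: the limit of > 50 nM in this assay, at which 1 of the 3 values shown sits.

The exchange of 4-cyanophenyl for 3-carboxypyridin-2-yl gives an at least 1.2-fold higher number from compound 2 to compound 3 (0.09 log units; that floor lies within the scatter), so this result alone does not show that the new ring and its carboxylic acid cost any inhibition, and the true number could lie close to that of compound 2 or well beyond it. The step between compound 1 and compound 3 cannot be read, so all this result shows at this position is a floor that stays within the usual scatter.

Compound 3 brings in the ring nitrogen and the carboxylic acid together, which leaves open what each does alone, as a plain pyridine ring or a phenyl ring carrying a carboxylic acid would separate them. Also open, going by these compounds, is whether a methyl ester or an amide in place of the carboxylic acid would return a number and not a limit.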